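Inverting the Chain Stereocentre of Compound 2

A few compounds are considered here, and "the series" means these few. Any claim that something is new, unique, unknown or untested is made for them only; others in the source may bear on it.

Measured so far:
Compound 1 `Cc1ccc(NC(=O)c2cccc(C(F)(F)F)c2)cc1C#Cc1nn(C[C@H](C)CO)c2ncnc(N)c12`: 10 nM
Compound 2 `Cc1ccc(NC(=O)c2ccc(C)c(C(F)(F)F)c2)cc1C#Cc1nn(C[C@@H](C)CO)c2ncnc(N)c12`: 48 nM

In a functional assay on MDA-MB-231 cells (Homo sapiens) for antiproliferative activity, read by MTT assay, with a stated time of 72 h (a lower number here means a stronger inhibitor, a higher number a weaker inhibitor), compound 1 gives 10 nM. For the measured compounds named here, compound 2 stands highest of the two numbers measured, and in this assay compound 2 gives 48 nM, its only neighbour being compound 1, whose number is lower by a gap beyond the scatter. Compound 3 `Cc1ccc(NC(=O)c2ccc(C)c(C(F)(F)F)c2)cc1C#Cc1nn(C[C@H](C)CO)c2ncnc(N)c12` is not yet measured. It differs from compound 2 as follows: the two compounds have the same atoms and bonds and differ only in configuration as drawn: 1 of 1 stereo elements differ; a stereocentre at a saturated chain carbon is drawn R in compound 2 and S in compound 3. Compound 3 carries the configuration drawn in compound 1 while keeping the amide of compound 2, so a moderate step downward is expected, a 2.4-fold lower number from compound 2 to compound 3 (0.38 log units; beyond the scatter), and compound 3 is estimated at 20 nM, within 6 nM to 60 nM.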

Compound 3, half-maximal inhibitory concentration: 43 nM
Estimate against measurement, compound 3: 2.2-fold (0.33 log units) below; measured number inside the range.
By their numbers in this assay, from the lowest: compound 1; then compounds 3 and 2 (each within the scatter of the next).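

With the methyl-bearing amide in place, inverting the chain stereocentre from R to S leaves the number in this assay unchanged within the scatter (a 1.1-fold lower number from compound 2 to compound 3 (0.05 log units; within the scatter)). This reading of configuration is a clean one: the fact that compounds 2 and 3 differ only in the configuration as drawn. The step that does register is methyl in place of hydrogen on an aromatic carbon (a 4.3-fold higher number from compound 1 to compound 3 (0.63 log units; beyond the scatter)), so the stereocentre is silent in this pair while that methyl is not.

As far as these compounds go, whether the stereocentre stays silent when that aromatic carbon carries hydrogen remains open. So does how a chlorine or a methoxy group would fare there.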